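Carbonyl substituent swap: expected rat cell cytotoxicity for compound 4

A few compounds are considered here, and "the series" means these few. Any claim that something is new, unique, unknown or untested is made for them only; others in the source may bear on it.

Among the measured compounds shown here, compound 3 `COc1cc(NC(C)CCCNC(=O)NNC(=O)/C(C)=C/c2ccccc2)c2ncccc2c1` gives 36500 nM in an ADME assay on L6 cells (Rattus norvegicus) for cytotoxicity, read by resazurin assay, with a stated time of 70 h (on this read-out lower numbers stand for stronger inhibition and higher numbers for weaker inhibition), and this is the only actual number in the set. Compound 1 `COc1ccc(/C=C/C(=O)NCCCC(C)Nc2cc(OC)cc3cccnc23)cc1` gives only a limit in this assay, > 240000 nM. That reading is recorded as a limit rather than a number, (the limit of > 240000 nM in this assay, at which 1 of the 3 values shown sits). For compound 2 `COc1cc(NC(C)CCCNC(=O)N(C2CCCCC2)C2CCCCC2)c2ncccc2c1` the entry in this assay reads "not determined" (no result reported). Compound 4 `COc1cc(NC(C)CCCNC(=O)NNC(=O)Nc2ccc(Cl)cc2)c2ncccc2c1` is not yet measured. It differs from compound 3 by (4-chlorophenyl)amino in place of 1-methyl-2-phenylethenyl on a carbonyl carbon, the change sitting on a carbonyl carbon whose other neighbour is an amide-type nitrogen; cut one bond further out, the same difference reads (1-methyl-2-phenylethenyl)carbonyl to (4-chlorophenyl)carbamoyl. For the measured compounds named here, no measured pair in the set differs in a single place, so the size of this step cannot be read off a neighbour and rests on compound 3 alone. The expectation for compound 4 is a moderate move toward weaker inhibition in this assay, a 1.9-fold higher number from compound 3 to compound 4 (0.28 log units; within the scatter). Compound 4 is therefore estimated at 70000 nM, with a range from 18000 nM to 240000 nM, and a fair chance remains that this assay returns only a limit for it.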

Compound 4, half-maximal inhibitory concentration: 91900 nM
The estimate for compound 4 lay 1.3-fold (0.12 log units) below the measured number; the measured number falls inside the stated range.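

The carbonyl carbon whose other neighbour is an amide-type nitrogen now has its first readable step in this assay: (4-chlorophenyl)amino in place of 1-methyl-2-phenylethenyl gives a 2.5-fold higher number from compound 3 to compound 4 (0.40 log units; beyond the scatter). Both groups carry a six-membered aromatic ring of carbon only, so this exchange at the position moves the reading modestly and still returns a number rather than a limit. Compound 1 remains the only compound in this series recorded as a limit, which is not a number: the limit of > 240000 nM in this assay, at which 1 of the 4 values shown sits.

This single step cannot separate the loss of the double bond from the entry of the amino nitrogen or the chlorine. From the compounds shown here alone, how a plain phenylamino group without the chlorine, or a longer chain on the same carbonyl carbon, would read in this assay stays open.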